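An Ethyl Group Added to a Core Beyond the Limit

The source may hold more compounds than are shown below. What is called first, only, known or untested is meant among the compounds shown, and "the series" means these compounds.

Compound 1 `Cc1ncn2c(O)nncc12` was examined in a functional assay for inhibition, with Homo sapiens as the target (a lower number here means a stronger inhibitor, a higher number a weaker inhibitor), where compound 1 gives > 48000 nM, a limit of the assay rather than a number. Within the data shown here, its one measured neighbour, compound 2 `CSc1nncc2c(C)ncn12`, carries methylsulfanyl in place of hydroxy on an aromatic carbon. In this assay compound 2 gives > 48000 nM, again a limit. The step that the two limits leave unreadable from compound 1 to compound 2 is thus unreadable, and the limit of > 48000 nM in this assay, at which 2 of the 2 values shown sit, is all that the pair reveals. Compound 3 `CCc1nc(C)c2cnnc(O)n12` carries ethyl in place of hydrogen on an aromatic carbon. Among the measured compounds shown here, no measured step bears on this change, so compound 3 is expected near 60000 nM, between 15000 nM and 200000 nM. The estimated step that the limit leaves unreadable from compound 1 to compound 3 is itself only a guess.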

Compound 3, half-maximal inhibitory concentration: > 48000 nM
Compound 3: no number, only a limit; the forecaster's own chance of this, stated with the estimate: 85%; the middle value is on the limit's open side.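

Among these compounds, with compound 3, as with compound 1, only a limit is given in this assay, so no step between them can be read: the limit of > 48000 nM in this assay, at which 3 of the 3 values shown sit. The compounds shown leave open how strongly any of them inhibits, and whether ethyl in place of hydrogen changes that.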